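The source may report more compounds than this note shows. Statements on the series, on what has been measured and on what is new or still open speak of the compounds shown alone.

Measured so far:
- compound 1, `CCc1nc(N)nc2c1c(-c1ccc3oc(N)nc3c1)nn2C(C)C`: < 5 uL/min
- compound 2, `COc1nc(N)nc2c1c(-c1ccc3oc(N)nc3c1)nn2C(C)C`: no result
- compound 3, `CC(C)n1nc(-c2ccc3oc(N)nc3c2)c2c(F)nc(N)nc21`: 57 uL/min

The readout throughout is an ADME assay on cells (Hepatocyte, Homo sapiens) for metabolic stability, read by LC-MS, with a stated time of 90 min, tested at 1 uM; a higher number here means faster removal of the compound, a lower number slower removal. For compound 1 the value of < 5 uL/min is a limit of the assay rather than a number; the limit of < 5 uL/min in this assay, at which 1 of the 3 values shown sits, marks that edge, and one of the three entries sits there. For compound 2 the result in this assay is "not determined" (no result reported), so no number exists for it. Compound 3 gives 57 uL/min in this assay.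

Among the measured compounds shown here, only one pair of measured compounds differs in a single place: an at least 11-fold higher number from compound 1 to compound 3 (1.05 log units; beyond the scatter). That is a large rise, well beyond the usual scatter, produced by fluoro in place of ethyl on an aromatic carbon.

The compound not yet measured is compound 4, `CC(C)n1nc(-c2ccc3oc(N)nc3c2)c2c(C#N)nc(N)nc21`. It differs from compound 2 by cyano in place of methoxy on an aromatic carbon. The measured step concerns other groups, so it bears only loosely on this change, and compound 2 itself has no number to start from. The expectation for compound 4 therefore rests on the span between compound 1 and compound 3: the estimate in this assay is 30 uL/min, within a range from 8 uL/min to 90 uL/min.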

Compound 4, intrinsic clearance in a liver preparation (reported as CLH), per the amount of preparation that the assay uses: < 5 uL/min
Compound 4 gave a limit, no number; the forecaster's own chance of this, stated with the estimate: 10%; middle value at least 6.0-fold (0.77 log units) away from the limit.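

In this assay, the group on this aromatic carbon can move the result strongly in both directions, not only upward as the earlier pair showed: an at least 11-fold lower number from compound 3 to compound 4 (1.05 log units; beyond the scatter). Swapping one small group for another at this single place is therefore enough to separate a compound with a clear readable value from one at the edge of the assay, and fluoro is so far the only group here with a real number. Compound 4, like compound 1, gives a limit and not a number, which places cyano and ethyl, two quite different groups, at the same edge, and the step between these two compounds cannot be read, so neither group can be ranked against the other: the limit of < 5 uL/min in this assay, at which 2 of the 4 values shown sit.

From the compounds shown here alone, compound 2 has no reported result, so it remains open whether methoxy falls with fluoro or with cyano and ethyl, and the direct comparison of cyano with methoxy has no size. Also open, going by these compounds, is where other groups on this carbon would fall, such as an amine, a chlorine atom, a carboxylic acid or a longer chain like propyl.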